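Moving a methyl group on the styryl aryl of compound 3

A few compounds are considered here, and "the series" means these few. Any claim that something is new, unique, unknown or untested is made for them only; others in the source may bear on it.

Compound 1 `O=C(/C(=C\c1ccc(O)c([N+](=O)[O-])c1)SCc1ccc(Br)cc1)c1c(F)c(F)c(F)c(F)c1F` gives 10000 nM
Compound 2 `O=C(/C(=C\c1ccc(O)c([N+](=O)[O-])c1)SCc1ccc(Cl)cc1)c1ccc(Cl)cc1` gives 10000 nM
Compound 3 `Cc1ccc(C)c(/C=C(\C(=O)c2ccc(Cl)cc2)S(=O)(=O)c2ccc(Br)cc2)c1` gives 1000 nM

All three values come from a functional assay on DU-145 cells (Homo sapiens) for inhibition, read by trypan blue exclusion, with a stated time of 96 h; a lower number here means a stronger inhibitor of growth, a higher number a weaker inhibitor of growth. Compound 3 has the lowest number of the three, and the equal values of compound 1 and compound 2 lie beyond the scatter above it. For the measured compounds named here, no pair of measured compounds differs in one place only, so the series offers no direct measure of what a single change does.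

Compound 4 `Cc1cc(C)cc(/C=C(\C(=O)c2ccc(Cl)cc2)S(=O)(=O)c2ccc(Br)cc2)c1` has the same atoms as compound 3, joined differently: 3,5-dimethylphenyl in place of 2,5-dimethylphenyl on a double-bonded chain carbon bound to a double-bonded chain carbon. The change places 3,5-dimethylphenyl in place of 2,5-dimethylphenyl on a double-bonded chain carbon bound to a double-bonded chain carbon.

The expectation rests on compound 3 at 1000 nM alone, and no shift beyond the scatter is expected in this assay. The expected change is a 1.2-fold higher number from compound 3 to compound 4 (0.08 log units; within the scatter). For compound 4 the estimated value is 1200 nM, with an expected range of 300 nM to 5000 nM.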

Compound 4, concentration for 50% growth inhibition: 10000 nM
Estimate against measurement, compound 4: 8.3-fold (0.92 log units) below; the measured number lies above the stated range.
By their numbers in this assay, from the lowest: compound 3; then compounds 1, 2 and 4 (each within the scatter of the next).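

In this assay, for the compounds shown here, this is the first step that changes one place only, and it gives a 10-fold higher number from compound 3 to compound 4 (1.00 log units; beyond the scatter) with the atoms unchanged. At this place, on a double-bonded chain carbon bound to a double-bonded chain carbon, 3,5-dimethylphenyl therefore does not stand in for 2,5-dimethylphenyl, and the number depends on how the two methyl groups are arranged on the ring, not just on their presence. Nothing measured here gives a reason for the size of this change.

On these data alone, whether compound 3 needs both methyl groups of its 2,5-dimethylphenyl remains open, as does whether a plain phenyl or a methoxyphenyl at this place would keep its number. Also open, as far as these compounds go, is whether the same exchange would matter as much with the other parts of the core altered.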